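Chain-extended ester analogue in the oxazole ketone series

The source may report more compounds than this note shows. Statements on the series, on what has been measured and on what is new or still open speak of the compounds shown alone.

Measured so far:
compound 1, `O=C(CCCCC#Cc1cccnc1)c1ncc(-c2ccccn2)o1`, 300 nM
compound 2, `COC(=O)CCCC(=O)c1ncc(-c2ccccn2)o1`, 7000 nM

In an assay for inhibition of Fatty-acid amide hydrolase 1 (Rattus norvegicus) (on this read-out lower numbers stand for stronger inhibition and higher numbers for weaker inhibition), compound 1 gives 300 nM. Compound 2 stands at the high end of the two numbers: in this assay compound 2 gives 7000 nM, and the gap to compound 1 lies beyond the scatter. Within the data shown here, no pair of measured compounds differs in one place, so no measured single step is available.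

Compound 3, `COC(=O)CCCCC(=O)c1ncc(-c2ccccn2)o1`, is not yet measured. It differs from compound 2 as follows: (methoxycarbonyl)methyl in place of methoxycarbonyl on a saturated chain carbon, three bonds along the chain from a carbonyl carbon. The change adds one saturated carbon to the chain between the carbonyl and the ester, with no change in ring count, donors or acceptors. With no measured step of this kind in the series, the expectation rests on the structural change alone: a small step, most likely toward a lower number, of a size that may well stay within the scatter, expected as a 1.8-fold lower number from compound 2 to compound 3 (0.24 log units; within the scatter). Compound 3 is therefore estimated at 4000 nM, with a range from 1500 nM to 10000 nM.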

Compound 3, inhibition constant: 1800 nM
The estimate for compound 3 lay 2.2-fold (0.35 log units) above the measured number, and the stated range covers the measured number.
By their numbers in this assay, from the lowest: compound 1; then compound 3; then compound 2.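

In this assay, among these compounds, (methoxycarbonyl)methyl in place of methoxycarbonyl gives a 3.9-fold lower number from compound 2 to compound 3 (0.59 log units; beyond the scatter), the first measured single step, and it shows that the number at this position responds to one added saturated chain carbon. At the chain end, methoxycarbonyl in place of 2-(pyridin-3-yl)ethynyl gives a 6.0-fold higher number from compound 1 to compound 3 (0.78 log units; beyond the scatter), so the ester chain of compound 3 still leaves a gap to compound 1 that lies beyond the scatter. Nothing at hand gives a cause for either step.

As far as these compounds go, whether a longer chain carrying the same ester would continue the direction of this single step stays open. Also open, from the compounds shown here alone, is how a carboxylic acid or an amine at the chain end would read in this assay.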